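A Fluoro Substitution Carried onto Compound 3

A few compounds are considered here, and "the series" means these few. Any claim that something is new, unique, unknown or untested is made for them only; others in the source may bear on it.

Compound 2 `CCCOC(=O)c1cc(N2C(=O)C3=C(CCCC3)C2=O)ccc1Cl` serves as the reference; in a functional assay on the whole organism with Scenedesmus acutus as the target, with a stated time of 20 h (on this read-out higher numbers stand for weaker inhibition and lower numbers for stronger inhibition), compound 2 gives 661 nM. Compound 1 `CCCOC(=O)c1cc(N2C(=O)C3=C(CCCC3)C2=O)c(F)cc1Cl` differs from it by fluoro in place of hydrogen on an aromatic carbon, a change that brings a 10-fold lower number from compound 2 to compound 1 (1.00 log units; beyond the scatter). In this assay compound 1 gives 66.1 nM. Compound 3 `CC(C)OC(=O)c1cc(N2C(=O)C3=C(CCCC3)C2=O)ccc1Cl` shares the core of compound 2 but differs by isopropyl in place of propyl on an oxygen next to a carbonyl group; in this assay compound 3 gives 182 nM, which amounts to a 3.6-fold lower number from compound 2 to compound 3 (0.56 log units; beyond the scatter).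

Compound 4 `CC(C)OC(=O)c1cc(N2C(=O)C3=C(CCCC3)C2=O)c(F)cc1Cl` has not yet been measured. It differs from compound 3 by fluoro in place of hydrogen on an aromatic carbon. The surroundings are not worded alike: in compound 1 the fluoro sits para to a propoxycarbonyl group, in compound 4 para to an isopropoxycarbonyl group, so this is the same kind of change rather than the same change. A step near the earlier one is expected because compound 1 showed a 10-fold lower number from compound 2 to compound 1 (1.00 log units; beyond the scatter), tempered slightly for the different core, giving an expected 8.3-fold lower number from compound 3 to compound 4 (0.92 log units; beyond the scatter). Compound 4 is thus estimated at 22 nM, between 8 nM and 60 nM.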

Compound 4, half-maximal inhibitory concentration: 89.1 nM
Compound 4: the middle estimate sits 4.1-fold (0.61 log units) below what was measured, outside the stated range (above it).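

In this assay the fluoro substitution keeps its direction on the core of compound 3, giving a 2.0-fold lower number from compound 3 to compound 4 (0.31 log units; beyond the scatter), but it does not keep its size: the same change on two cores in this assay, a 10-fold lower number (1.00 log units; beyond the scatter) from compound 2 to compound 1 and a 2.0-fold lower number (0.31 log units; beyond the scatter) from compound 3 to compound 4, 4.9-fold (0.69 log units) apart, beyond the scatter of two such steps

The exchange of propyl for isopropyl carries over no better, giving a 1.3-fold higher number from compound 1 to compound 4 (0.13 log units; within the scatter) once fluoro is present: the same change on two cores in this assay, a 3.6-fold lower number (0.56 log units; beyond the scatter) from compound 2 to compound 3 and a 1.3-fold higher number (0.13 log units; within the scatter) from compound 1 to compound 4, 4.9-fold (0.69 log units) apart, beyond the scatter of two such steps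

The two changes therefore do not simply add up across these four compounds, but this single set of four cannot show what lies behind the gap or whether it would recur on other cores.

On these data alone, it remains open whether chloro or bromo in place of the fluoro would behave the same way. The same holds for a butyl or tert-butyl chain in place of the isopropyl.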